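This account rests on a few compounds, and the source may have more. Where it says the series, first, only, none or still open, it means among the compounds named here.

Compound 1 `CC1(C)Cc2c(sc(NC(=O)c3cn[nH]c3)c2C(N)=O)C(C)(C)O1`: 125 nM
Compound 2 `CC1(C)Cc2c(sc(NC(=O)C(C)(C)CO)c2C(N)=O)C(C)(C)O1`: 75 nM

Both numbers come from an assay on cells for positive allosteric modulation of Cystic fibrosis transmembrane conductance regulator variant F508del (Homo sapiens), with stated times of 10 min and 7 s, in the presence of a further agent that is not named here; a higher number here means that more compound is needed for the effect, a lower number that less compound is needed. Among the compounds with values here, compound 1 gives 125 nM there, and the only other measured compound, compound 2, is reached by a 1.7-fold lower number from compound 1 to compound 2 (0.22 log units; within the scatter), so on these numbers the two compounds cannot be told apart.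

Compound 3 `Cc1n[nH]c(C(=O)Nc2sc3c(c2C(N)=O)CC(C)(C)OC3(C)C)c1Cl` has not been measured in this assay. It differs from compound 1 in one place: a group of 7 heavy atoms (4 carbon, 2 nitrogen, 1 chlorine; one five-membered aromatic ring with 2 hetero atoms) in place of a group of 5 heavy atoms (3 carbon, 2 nitrogen; one five-membered aromatic ring with 2 hetero atoms), on a carbonyl carbon. Within the data shown here, the only measured step that touches the same carbonyl carbon, a 1.7-fold lower number from compound 1 to compound 2 (0.22 log units; within the scatter), replaced the aromatic ring with a group that has no ring and still stayed within the scatter, so the numbers seen so far moved little when this position was changed. That step involved a different group, however, and offers no direct guide to a substituted ring. Compound 3 is therefore expected to give about 110 nM, with an estimated range from 40 nM to 350 nM. The expected step is a 1.1-fold lower number from compound 1 to compound 3 (0.06 log units; within the scatter), nothing beyond the scatter.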

Compound 3, half-maximal effective concentration: 11 nM
Beside the measured number, compound 3's estimate is 10-fold (1.00 log units) above it; measured number outside the range, below it.
By their numbers in this assay, from the lowest: compound 3; then compounds 2 and 1 (each within the scatter of the next).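

Within the data shown here, the position on the carbonyl carbon is more sensitive than the earlier compounds suggested: keeping a five-membered aromatic ring with 2 hetero atoms but changing the group gives an 11-fold lower number from compound 1 to compound 3 (1.06 log units; beyond the scatter), a step beyond the scatter. The new ring also beats the group without a ring, with a 6.8-fold lower number from compound 2 to compound 3 (0.83 log units; beyond the scatter), so the ring of compound 1 and the open chain of compound 2 both fall short of it, even though compound 1 and compound 3 have the same counts of hydrogen-bond donors and acceptors. Nothing measured here bears on the reason for this gain.

The added chlorine, the added carbon and the different way the ring is attached all change together, so the compounds shown cannot say which of them matters. On these data alone, how a ring carrying bromine instead of chlorine would behave also remains open.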